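From hydroxy to methoxy on compound 1

The source may report more compounds than this note shows. Statements on the series, on what has been measured and on what is new or still open speak of the compounds shown alone.

- compound 1 (`C=C1CC[C@H]2C(C)(C)CCC[C@]2(C)[C@H]1CC/C(C)=C/Cc1c(O)cc(O)c2c(=O)c(O)c(-c3ccc(O)cc3)oc12`) gives 29000 nM in a functional assay on HT-29 cells (Homo sapiens) for cytotoxicity, read by XTT assay, with a stated time of 72 h; a lower number here means a stronger inhibitor, a higher number a weaker inhibitor
- compound 2 (`CC(C)=CCC/C=C(\C)Cc1c(OC/C=C(\C)CCC=C(C)C)c(C/C=C(\C)CCC=C(C)C)c(O)c2c(=O)cc(-c3ccccc3)oc12`) gives 32000 nM in this assay

Compound 1 and compound 2 lie within the usual scatter of each other in this assay, so the two cannot be ranked. Compound 3 (`C=C1CC[C@H]2C(C)(C)CCC[C@]2(C)[C@H]1CC/C(C)=C/Cc1c(O)cc(O)c2c(=O)c(O)c(-c3ccc(OC)cc3)oc12`) differs from compound 1 in one place: methyl in place of hydrogen on an oxygen on an aromatic ring, which is methyl in place of hydrogen on an oxygen on an aromatic ring, turning 4-hydroxyphenyl into 4-methoxyphenyl. Within the data shown here, no measured pair shows this change, so the data give no size for it. No step beyond the scatter is expected in this assay, and neither direction is favoured. The estimated change a 1.0-fold higher number from compound 1 to compound 3 (0.01 log units; within the scatter) is therefore expected to be small. The estimate for compound 3 is 30000 nM (expected range 12000 nM to 75000 nM).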

Compound 3, half-maximal inhibitory concentration: > 100000 nM
Compound 3: only a limit was reported (the forecaster's own chance of this, stated with the estimate: 20%); middle value at least 3.3-fold (0.52 log units) away from the limit.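

Among these compounds, this is the first pair that differs in one place, and turning 4-hydroxyphenyl into 4-methoxyphenyl gives an at least 3.4-fold higher number from compound 1 to compound 3 (0.53 log units; beyond the scatter) in this assay, so methyl in place of hydrogen on this oxygen is not a neutral change here. Compound 3 gives > 100000 nM, which is a limit of the assay and not a number. The step therefore has a lower bound only, and its full size stays unknown: the limit of > 100000 nM in this assay, at which 1 of the 3 values shown sits.

The compounds shown leave open whether a free hydroxy is what this position needs, or whether methyl is simply one poor choice there. An amine in place of the hydroxy, a longer chain such as ethyl on the same oxygen, or methyl on the other hydroxy groups of the shared core could each tell these readings apart.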